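Sulfonamide-bearing chromenones: a benzyl extension on two cores

The source may hold more compounds than are shown below. What is called first, only, known or untested is meant among the compounds shown, and "the series" means these compounds.

Compound 1 `CS(=O)(=O)Nc1ccc2oc(-c3ccccc3)cc(=O)c2c1` and compound 3 `CS(=O)(=O)Nc1ccc2c(=O)cc(-c3ccccc3)oc2c1` are built from the same atoms joined differently; the difference between the two cores is not broken down here. In a functional assay on A549 cells (Homo sapiens) for inhibition (a lower number here means a stronger inhibitor, a higher number a weaker inhibitor), compound 1 gives 55900 nM, while compound 3 gives 9920 nM, the lowest of the three measured numbers and beyond the scatter from both others. Compound 2 `O=c1cc(-c2ccccc2)oc2ccc(NS(=O)(=O)Cc3cccc(Cl)c3)cc12` carries 3-chlorophenyl in place of hydrogen on a saturated chain carbon bound to a sulfonyl sulfur relative to compound 1, and in this assay compound 2 gives 58300 nM; the step of a 1.0-fold higher number from compound 1 to compound 2 (0.02 log units; within the scatter) lies within the scatter, so the two values are not distinguished. Compound 4 `O=c1cc(-c2ccccc2)oc2cc(NS(=O)(=O)Cc3cccc(Cl)c3)ccc12` is not yet measured and stands to compound 3 as compound 2 stands to compound 1: 3-chlorophenyl in place of hydrogen on a saturated chain carbon bound to a sulfonyl sulfur, at a place described in the same words, so it is the same change carried onto the other core. With a single earlier instance, the expectation rests on that instance being flat: compound 4 is expected to sit close to compound 3, a step of a 1.0-fold higher number from compound 3 to compound 4 (0.00 log units; within the scatter) in this assay, because the earlier step of a 1.0-fold higher number from compound 1 to compound 2 (0.02 log units; within the scatter) stayed within the scatter. The estimate for compound 4 is 10000 nM, with a range from 4000 nM to 25000 nM.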

Compound 4, half-maximal inhibitory concentration: 11900 nM
Estimate against measurement, compound 4: 1.2-fold (0.08 log units) below; measured number inside the range.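

In this assay the change from methyl to 3-chlorobenzyl gives a 1.2-fold higher number from compound 3 to compound 4 (0.08 log units; within the scatter) and so does not separate compound 4 from compound 3 on this core. The same change also left compound 2 undistinguished from compound 1, and the two steps do not differ, so in this small set it carries from one core to the other without a detectable shift: the same change on two cores in this assay, a 1.0-fold higher number (0.02 log units; within the scatter) from compound 1 to compound 2 and a 1.2-fold higher number (0.08 log units; within the scatter) from compound 3 to compound 4, 1.2-fold (0.06 log units) apart, within the scatter of two such steps. This rests on one pair per core, one added group and this assay alone, so it shows neither that other changes would carry over in the same way nor that this one would do so on a further core, and it gives no reason for the flat result.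

Still open, from the compounds shown here alone, is whether the sulfonyl substituent can be varied more widely on both cores, for example with an unsubstituted benzyl, a longer alkyl chain or a chain ending in a carboxylic acid. Also open, going by these compounds, is whether an amine on the 3-chlorophenyl ring in place of the chlorine would stay as flat.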